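The source may hold more compounds than are shown below. What is called first, only, known or untested is meant among the compounds shown, and "the series" means these compounds.

compound 1 `CCCCO[C@@H]1C=CC(=O)[C@@H](COC(=O)C(C)(C)C)O1`: 42500 nM
compound 2 `CC(=O)OC[C@H]1O[C@H](OCCC(C)C)C=C([C@H](O)c2ccc([N+](=O)[O-])cc2)C1=O`: 14300 nM

The measurements so far come from an ADME assay on Vero cells (Chlorocebus sabaeus) for cytotoxicity, read by resazurin assay, with a stated time of 24 h; on this read-out lower numbers stand for higher toxicity in this test and higher numbers for lower toxicity in this test. Of the two compounds tested, compound 1 has the higher number at 42500 nM, and compound 2 sits at 14300 nM, a gap beyond the usual scatter. The next compound to be tested is compound 3 `CC(C)(C)C(=O)OC[C@H]1O[C@H](OCC2CC2)C=CC1=O`. It differs from compound 1 in one place: cyclopropyl in place of propyl on a saturated chain carbon bound to an oxygen on a saturated carbon. This puts cyclopropyl in place of propyl on a saturated chain carbon bound to an oxygen on a saturated carbon, so butoxy becomes cyclopropylmethoxy. For the measured compounds named here, no measured pair isolates a single change, so the data offer no direct guide, and no step beyond the scatter is expected in this assay. The expected change is a 1.2-fold lower number from compound 1 to compound 3 (0.07 log units; within the scatter). The estimate for compound 3 is 36000 nM, with an expected range of 15000 nM to 85000 nM.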

Compound 3, half-maximal cytotoxic concentration: 77200 nM
Estimate against measurement, compound 3: 2.1-fold (0.33 log units) below; the measured number falls inside the stated range.
By their numbers in this assay, from the lowest: compound 2; then compounds 1 and 3 (each within the scatter of the next).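

In this assay, for the compounds shown here, this is the first pair of compounds that differ in only one place, so it is the first direct look at what a change on this chain can do. Putting cyclopropyl in place of propyl on a saturated chain carbon bound to an oxygen on a saturated carbon, which turns butoxy into cyclopropylmethoxy, gives a 1.8-fold higher number from compound 1 to compound 3 (0.26 log units; within the scatter), so closing the end of the chain into a three-membered ring has no effect that can be told apart from repeat-to-repeat variation. No separate measurement bears on this result.

This single pair cannot show how far the position tolerates change in general. From the compounds shown here alone, whether a longer chain, an amine or a carboxylic acid at this place would shift the number beyond the scatter remains open.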